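The source may hold more compounds than are shown below. What is called first, only, known or untested is meant among the compounds shown, and "the series" means these compounds.

Measured in a functional assay on KG-1 cells (Homo sapiens) for cytotoxicity, read by luminescence and CellTiter-Glo, with a stated time of 3 days; on this read-out lower numbers stand for stronger inhibition and higher numbers for weaker inhibition:
- compound 1 `COc1ccc(C(=O)Nc2ccc(C#N)cc2)c(O)c1`: 5430 nM
- compound 2 `O=C(Nc1cccc(C(F)(F)F)c1)c1cc(F)ccc1O`: 1010 nM
- compound 3 `O=C(Nc1cccc(OC(F)(F)F)c1)c1cc(F)ccc1O`: 830 nM

Compound 1 has the highest number of the three, so it is the least potent here, and its gaps to the other two lie beyond the scatter. The next compound, compound 4 `N#Cc1ccc(NC(=O)c2ccc(F)cc2O)cc1`, keeps the nitrile-bearing part of compound 1 and changes one group on the other ring: fluoro in place of methoxy on an aromatic carbon.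

For the measured compounds named here, no measured step makes this exact change. Going by the values given here, the only step available, a 1.2-fold lower number from compound 2 to compound 3 (0.09 log units; within the scatter), swaps trifluoromethyl for trifluoromethoxy and stays within the scatter, so it says little about the methoxy group. Compounds 2 and 3 do carry a fluoro, but they differ from compound 4 elsewhere too, so they offer only indirect support. Even so, compound 2 at 1010 nM and compound 3 at 830 nM suggest that a fluoro compound can reach lower numbers than compound 1, so a moderate drop is expected rather than a large one. The expected change is a 2.2-fold lower number from compound 1 to compound 4 (0.34 log units; beyond the scatter). Compound 4 is estimated at 2500 nM, with an expected range of 900 nM to 6500 nM.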

Compound 4, half-maximal inhibitory concentration: 3150 nM
Beside the measured number, compound 4's estimate is 1.3-fold (0.10 log units) below it; measured number inside the range.
By their numbers in this assay, from the lowest: compounds 3 and 2 (each within the scatter of the next); then compounds 4 and 1 (each within the scatter of the next).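

In this assay the step for fluoro in place of methoxy is a 1.7-fold lower number from compound 1 to compound 4 (0.24 log units; within the scatter) and stays within the scatter, so this swap gives no real separation between the two compounds. For the compounds shown here, this is the first direct look at this position, an aromatic carbon meta to a hydroxy group and para to a large group, and it shows that a methoxy group can give way to a smaller fluoro, which has no hydrogen-bond acceptor counted, without a change that can be told from assay noise. The data at hand hold no measurement that could explain this outcome.

As far as these compounds go, it remains open whether any group at this position can move the number beyond the scatter, for example an amine, a carboxylic acid, or a longer chain such as ethoxy. From the compounds shown here alone, this reading also comes from a single pair that carries the nitrile on the other ring, so it remains unknown whether the same swap would behave alike with trifluoromethyl or trifluoromethoxy on that ring.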